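The compounds below may be only part of what the source reports. "The series", "measured", "known", "first", "only" and "open" are said of these compounds alone.

In an assay on HEK293 cells for displacement of a labelled ligand from Melanocortin receptor 4 (Homo sapiens); on this read-out higher numbers stand for weaker inhibition and lower numbers for stronger inhibition:
compound 1 `CC(C)C[C@H](N)c1cc(C(F)(F)F)ccc1N1CCN(C(=O)C(C)Cc2ccc(Cl)c(Cl)c2)CC1` gives 120 nM; 1600 nM (2 entries)
compound 2 `CC(C)C[C@H](N)c1cc(C(F)(F)F)ccc1N1CCN(C(=O)COc2cccc(Cl)c2Cl)CC1` gives 2500 nM
compound 3 `CC(C)C[C@H](N)c1cc(C(F)(F)F)ccc1N1CCN(C(=O)COc2ccc(O)cc2)CC1` gives 4600 nM

Compound 3 stands as the highest of the two single numbers in this assay; its nearest neighbour is compound 2, and the step of a 1.8-fold higher number from compound 2 to compound 3 (0.26 log units; within the scatter) lies within the scatter, so the two are not separated. Compound 1 carries two entries in this assay, (the several entries of compound 1 in this assay, 120 nM; 1600 nM (2 entries)), which themselves spread widely and give no single number to set beside the others.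

Compound 4 `CC(C)C[C@H](N)c1cc(C(F)(F)F)ccc1N1CCN(C(=O)COc2cccc(Cl)c2)CC1` is to be measured. It differs from compound 3 by 3-chlorophenyl in place of 4-hydroxyphenyl on an oxygen on a saturated carbon. For the measured compounds named here, the only measured step bearing on this position is a 1.8-fold higher number from compound 2 to compound 3 (0.26 log units; within the scatter), where a 2,3-dichlorophenyl gave way to a 4-hydroxyphenyl with a change within the scatter. A 3-chlorophenyl sits between those two in what it carries, and nothing in the measured steps points to a shift beyond the scatter in this assay in either direction; if anything, the number for compound 4 is expected to return toward that of compound 2, 2500 nM.

Compound 4 is therefore expected at about 3000 nM, with a range of 1000 nM to 9000 nM, which means an expected step of a 1.5-fold lower number from compound 3 to compound 4 (0.19 log units; within the scatter).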

Compound 4, inhibition constant: 2600 nM
For compound 4 the middle estimate is 1.2-fold (0.06 log units) above the measured one, within the range that was stated.
By their numbers in this assay, from the lowest: compounds 2, 4 and 3 (each within the scatter of the next).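

In this assay, three aryl groups on the oxygen on a saturated carbon can now be read together, and compound 4 is not separated from compound 3 (a 1.8-fold lower number from compound 3 to compound 4 (0.25 log units; within the scatter)) or from compound 2 (a 1.0-fold higher number from compound 2 to compound 4 (0.02 log units; within the scatter)). For the compounds shown here, the first step exchanges 4-hydroxyphenyl, with its hydrogen-bond donor and acceptor, for 3-chlorophenyl, which has neither, and the second gives the first reading of hydrogen in place of chloro on an aromatic carbon of this group; neither change leaves the scatter, so at this level of resolution the position shows no dependence on the hydroxy group or on the second chloro. No measurement given here bears on why these three compounds sit together.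

Still open, going by these compounds, is whether any group at this position moves the number beyond the scatter, for instance an amine or a carboxylic acid on the phenyl ring, or a longer chain between the oxygen and the carbonyl. The part played by the oxygen itself also remains unresolved, since compound 1 differs from these compounds in more than one place and gives 120 nM; 1600 nM (2 entries) rather than a single number.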